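From tert-Butyl to 2,2-Difluoroethyl on the Ring Oxygen

The source may hold more compounds than are shown below. What is called first, only, known or untested is meant among the compounds shown, and "the series" means these compounds.

Of the compounds shown here, two have so far been measured in an assay on isolated protein for inhibition of protein kinase C delta type (Homo sapiens), read by TR-FRET, with a stated time of 2 h; on this read-out higher numbers stand for weaker inhibition and lower numbers for stronger inhibition. Compound 1 `COc1ncncc1CNc1cc(N[C@H]2CC[C@@H](O)CC2)c(C#N)cn1` gives 800 nM in this assay, and compound 2 `CC(C)(C)Oc1ncncc1CNc1cc(N[C@H]2CC[C@@H](O)CC2)c(C#N)cn1` gives 200 nM. Within the data shown here, compound 2 thus stands lowest of the two numbers, and the single step joining them is a 4.0-fold lower number from compound 1 to compound 2 (0.60 log units; beyond the scatter), a modest change brought about by tert-butyl in place of methyl on the oxygen. Compound 3 `N#Cc1cnc(NCc2cncnc2OCC(F)F)cc1N[C@H]1CC[C@@H](O)CC1` has not yet been measured; it differs from compound 2 in that (2,2-difluoroethyl in place of tert-butyl on an oxygen on an aromatic ring). Among the measured compounds shown here, the only measured step that bears on this exchange is a 4.0-fold lower number from compound 1 to compound 2 (0.60 log units; beyond the scatter), which concerned the same oxygen. Since the incoming group is neither methyl nor tert-butyl, compound 3 is expected to give back part of that gain, an estimated step of a 2.0-fold higher number from compound 2 to compound 3 (0.30 log units; within the scatter) in this assay. Compound 3 is accordingly estimated at 400 nM, with a range from 150 nM to 1000 nM.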

Compound 3, half-maximal inhibitory concentration: 90 nM
Compound 3: middle estimate off by 4.4-fold (0.65 log units), on the high side, and the stated range ends above it.
By their numbers in this assay, from the lowest: compound 3; then compound 2; then compound 1.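

In this assay, the substituent on this oxygen can take the number lower than tert-butyl did, with a 2.2-fold lower number from compound 2 to compound 3 (0.35 log units; beyond the scatter), and the full distance from methyl is an 8.9-fold lower number from compound 1 to compound 3 (0.95 log units; beyond the scatter). The two groups exchanged in the latest step have the same count of heavy atoms and differ in that two fluorine atoms and two carbons replace four carbons, so among these three compounds the order does not follow the heavy-atom count alone. No measurement is available here that accounts for the lower number with 2,2-difluoroethyl.

The compounds shown leave open whether the fluorine atoms themselves carry the difference, which a plain ethyl group on this oxygen would test. From the compounds shown here alone, how a 2,2,2-trifluoroethyl group would compare in this assay also remains open.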